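Aryloxy analogue: chloro in place of methyl on the phenyl ring

The source may report more compounds than this note shows. Statements on the series, on what has been measured and on what is new or still open speak of the compounds shown alone.

Compound 1 `CCCCOc1ccc2nncn2n1`: in a functional assay on the whole organism with Mus musculus as the target (on this read-out higher numbers stand for an effect only at larger amounts of compound and lower numbers for an effect already at smaller amounts), compound 1 gives > 100 mg/kg, a limit of the assay.
Compound 2 `CCCCCOc1ccc2nncn2n1`: in this assay compound 2 gives 39.4 mg/kg.
Compound 3 `Cc1cccc(Oc2ccc3nncn3n2)c1`: in this assay compound 3 gives > 100 mg/kg, a limit of the assay.

Compound 3 therefore stands only at a limit of this assay, not at a number, and it shares this position with compound 1 (the limit of > 100 mg/kg in this assay, at which 2 of the 3 values shown sit). Among the three measured compounds only compound 2 gives a number.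

Compound 4 `Clc1cccc(Oc2ccc3nncn3n2)c1` differs from compound 3 by chloro in place of methyl on an aromatic carbon.

Within the data shown here, the single measured step, an at least 2.5-fold lower number from compound 1 to compound 2 (0.40 log units; beyond the scatter), concerns lengthening of an alkyl chain on the ether oxygen and does not bear on an exchange of one aromatic substituent for another. Among the measured compounds shown here, no measured step touches the phenyl ring at all, so the change to compound 4 rests on no comparison.

With compound 3 at a limit, the expectation for compound 4 is that it also sits near that limit, with a step that the limit leaves unreadable from compound 3 to compound 4 expected to be no step beyond the scatter. Compound 4 is therefore estimated at 120 mg/kg in this assay, with a range from 40 mg/kg to 400 mg/kg, and a limit rather than a number is the likelier report.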

Compound 4, dose for half-maximal effect: 39.4 mg/kg
For compound 4 the middle estimate is 3.0-fold (0.48 log units) above the measured one; the measured number lies below the stated range.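

Chloro in place of methyl on an aromatic carbon, meta to a large group, gives an at least 2.5-fold lower number from compound 3 to compound 4 (0.40 log units; beyond the scatter). The phenyl ring of the aryloxy compounds is thus a place where a change of substituent registers in this assay, and an aryloxy compound can give a number there rather than a limit. The size of the step is only a bound, since compound 3 stands at a limit of the assay: the limit of > 100 mg/kg in this assay, at which 2 of the 4 values shown sit.

From the compounds shown here alone, whether this lower number belongs to chloro alone stays open, as fluoro, trifluoromethyl, methoxy or an amine at the same place could read differently. Also open, going by these compounds, are how the unsubstituted phenyl ring reads and whether chloro elsewhere on that ring keeps the effect.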